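Series notes: hydrogen for 4-chlorobenzyl on the ring nitrogen

The source may report more compounds than this note shows. Statements on the series, on what has been measured and on what is new or still open speak of the compounds shown alone.

The series is followed in an ADME assay on HEK-293T cells (Homo sapiens) for cytotoxicity, read by MTT assay, with a stated time of 48 h, in the presence of a further agent that is not named here; a lower number here means a stronger inhibitor, a higher number a weaker inhibitor. Compound 1 `O=C(NCc1ccccc1)c1csc(-c2c[nH]c3ccccc23)n1` gives 74500 nM. For compound 2 `O=C(Nc1ccccc1)c1csc(-c2cn(Cc3ccc(Cl)cc3)c3ccccc23)n1` the assay reports only a limit, > 100000 nM, so compound 2 stands at the limit of > 100000 nM in this assay, at which 1 of the 2 values shown sits, and not at a number; where it sits relative to compound 1 cannot be read off. Compound 3 `O=C(Nc1ccccc1)c1csc(-c2c[nH]c3ccccc23)n1` is the unmeasured member. It differs from compound 2 by hydrogen in place of 4-chlorobenzyl on an aromatic nitrogen. Among the measured compounds shown here, no measured pair shows this change in this assay, so no step size is available from the data; compound 1 also carries hydrogen at that nitrogen and sits at a weak number, which gives no ground to expect a large shift. For compound 3 the expected step is an at least 1.2-fold lower number from compound 2 to compound 3 (0.09 log units; that floor lies within the scatter), within the scatter. Compound 3 is estimated at 80000 nM, between 30000 nM and 200000 nM, with a real chance that only a limit is reported.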

Compound 3, half-maximal inhibitory concentration: > 100000 nM
Compound 3: no number, only a limit; the forecaster's own chance of this, stated with the estimate: 45%; at least 1.2-fold (0.09 log units) between middle value and limit.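

With 4-chlorobenzyl gone from the aromatic nitrogen, compound 3 also gives only a limit in this assay, > 100000 nM. Among the compounds shown here, the steps that end on two limits cannot be read, so this assay puts no order on hydrogen and 4-chlorobenzyl at this position, and no size can be tied to the change: the limit of > 100000 nM in this assay, at which 2 of the 3 values shown sit. On the amide-type nitrogen, phenyl in place of benzyl gives an at least 1.3-fold higher number from compound 1 to compound 3 (0.12 log units; that floor lies within the scatter), the first step that can be read, though only as a floor.

Open, on these data alone, is whether another group on the aromatic nitrogen, such as an aminoethyl chain or a carboxymethyl group, would give a number rather than a limit in this assay. Also open, as far as these compounds go, is how 4-chlorobenzyl on that nitrogen reads with benzyl on the amide-type nitrogen.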